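The source may hold more compounds than are shown below. What is called first, only, known or untested is meant among the compounds shown, and "the series" means these compounds.

Working notes on the series. Three compounds share one core and have been run in a functional assay on MCF7 cells (Homo sapiens) for antiproliferative activity, read by MTT assay, with a stated time of 48 h; on this read-out lower numbers stand for stronger inhibition and higher numbers for weaker inhibition. Compound 1, `COc1cc(-c2nnc3c(OCC(F)(F)F)cc(-c4ccc5[nH]ccc5c4)cn23)cc(OC)c1OC`, gives 608 nM in this assay. Compound 2, `COc1cc(-c2nnc3c(OC4CCC4)cc(-c4ccc5[nH]ccc5c4)cn23)cc(OC)c1OC`, gives 267 nM. Compound 3, `COc1cc(-c2nnc3c(OCC(F)(F)F)cc(-c4ccc5c(ccn5C)c4)cn23)cc(OC)c1OC`, gives 382 nM.

Two single changes link the measured compounds. From compound 1 to compound 2 the change is cyclobutyl in place of 2,2,2-trifluoroethyl on an oxygen on an aromatic ring, and the step is a 2.3-fold lower number from compound 1 to compound 2 (0.36 log units; beyond the scatter). From compound 1 to compound 3 the change is methyl in place of hydrogen on an aromatic nitrogen, and the step is a 1.6-fold lower number from compound 1 to compound 3 (0.20 log units; within the scatter); compounds 2 and 3 are likewise within the scatter of each other, so no order is read among them.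

Compound 4, `COc1cc(-c2nnc3c(OC4CCC4)cc(-c4ccc5c(ccn5C)c4)cn23)cc(OC)c1OC`, is not yet measured. It differs from compound 3 by cyclobutyl in place of 2,2,2-trifluoroethyl on an oxygen on an aromatic ring. This is the same change as from compound 1 to compound 2, made twice in all among these compounds, and the place is the same word for word in both cases. The cores of compounds 1 and 3, and so of compounds 2 and 4, differ by methyl in place of hydrogen on an aromatic nitrogen.

Expectation for compound 4 in this assay rests on the single measured instance of this change, the step from compound 1 to compound 2 of a 2.3-fold lower number from compound 1 to compound 2 (0.36 log units; beyond the scatter), applied to the value of compound 3, 382 nM. The step from compound 3 to compound 4 is estimated at a 2.2-fold lower number from compound 3 to compound 4 (0.35 log units; beyond the scatter), on the assumption that the core difference does not alter it. Compound 4 is accordingly expected to give about 170 nM, with a range of 90 nM to 330 nM allowing for scatter and for a single precedent.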

Compound 4, half-maximal inhibitory concentration: 125 nM
Compound 4: middle estimate off by 1.4-fold (0.13 log units), on the high side; the measured number falls inside the stated range.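

In this assay, cyclobutyl in place of 2,2,2-trifluoroethyl on the oxygen gives a 3.1-fold lower number from compound 3 to compound 4 (0.49 log units; beyond the scatter), so the change keeps its direction on the second core, and the two steps do not differ in size: the same change on two cores in this assay, a 2.3-fold lower number (0.36 log units; beyond the scatter) from compound 1 to compound 2 and a 3.1-fold lower number (0.49 log units; beyond the scatter) from compound 3 to compound 4, 1.3-fold (0.13 log units) apart, within the scatter of two such steps. Methyl in place of hydrogen on the aromatic nitrogen gives a 2.1-fold lower number from compound 2 to compound 4 (0.33 log units; beyond the scatter), which is beyond the scatter, whereas its earlier step on the other core was within it, yet these two steps do not differ from each other either: the same change on two cores in this assay, a 1.6-fold lower number (0.20 log units; within the scatter) from compound 1 to compound 3 and a 2.1-fold lower number (0.33 log units; beyond the scatter) from compound 2 to compound 4, 1.3-fold (0.13 log units) apart, within the scatter of two such steps. Each change therefore carries between these two cores with no readable gap, but this rests on a single pair of steps per change in a single assay and does not show that either change would carry to any other core.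

Still open, from the compounds shown here alone, is whether the cyclobutyl step holds against other groups on the oxygen, such as a longer chain or a chain ending in an amine. Also open, going by these compounds, is whether the methyl step extends to other groups on the aromatic nitrogen, such as ethyl or a chain bearing a carboxylic acid.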